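Swapping chloro for hydroxy on a shared core

The compounds below may be only part of what the source reports. "The series", "measured", "known", "first", "only" and "open" are said of these compounds alone.

Of the compounds shown here, three built on one shared core have been tested for how far they hold back swelling in a rat paw, and a fourth awaits its measurement. Compound 1 `N#Cc1c(Nc2ccc(Cl)cc2)nc(SCC(=O)Nn2c(COc3ccc(Cl)cc3Cl)nc3ccccc3c2=O)nc1-c1ccccc1` is the starting point. In a functional assay on the whole organism (strain albino) for inhibition, with Rattus norvegicus as the target, read by paw edema, with stated times of 1 h and 0.5 h, at a dose of 100 mg/kg by the oral route (a higher number here means more inhibition at the dose given (going by the name of the read-out), a lower number less inhibition), compound 1 gives 51.9%. Compound 2 `N#Cc1c(Nc2ccc(O)cc2)nc(SCC(=O)Nn2c(COc3ccc(Cl)cc3Cl)nc3ccccc3c2=O)nc1-c1ccccc1` differs from compound 1 in one place, (hydroxy in place of chloro on an aromatic carbon), and in this assay compound 2 gives 61.5%. The change made this step: a number 9.6 percentage points higher from compound 1 to compound 2 (within the scatter). Compound 3 `N#Cc1c(Nc2ccc(Cl)cc2)nc(SCC(=O)Nn2c(COc3ccc(Cl)cc3Cl)nc3ccccc3c2=O)nc1-c1ccc(O)cc1` differs from compound 1 in another place, (hydroxy in place of hydrogen on an aromatic carbon), and in this assay compound 3 gives 65.4%. That change made this step: a number 13.5 percentage points higher from compound 1 to compound 3 (beyond the scatter). The values of compound 2 and compound 3 lie within the usual scatter of each other.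

Compound 4 `N#Cc1c(Nc2ccc(O)cc2)nc(SCC(=O)Nn2c(COc3ccc(Cl)cc3Cl)nc3ccccc3c2=O)nc1-c1ccc(O)cc1` has not yet been measured. It differs from compound 3 by hydroxy in place of chloro on an aromatic carbon, the same change that turns compound 1 into compound 2, now made on the core of compound 3 rather than the core of compound 1. The step from compound 3 to compound 4 is expected to be small, estimated as a number 6.6 percentage points higher from compound 3 to compound 4 (within the scatter). This expectation rests on compound 1 and compound 2, whose step a number 9.6 percentage points higher from compound 1 to compound 2 (within the scatter) stayed within the scatter. Compound 4 is therefore expected to give about 72% in this assay, most likely between 60% and 84%.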

Compound 4, a percentage reported as inhibition, in the whole organism at one dose (the size of the read-out at that dose, not a potency): 80.8%
Compound 4: middle estimate off by 8.8 percentage points, on the low side, within the range that was stated.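

On the core of compound 3, hydroxy in place of chloro gives a number 15.4 percentage points higher from compound 3 to compound 4 (beyond the scatter) in this assay, and this step can be set beside the same change on the core of compound 1: the same change on two cores in this assay, a number 9.6 percentage points higher (within the scatter) from compound 1 to compound 2 and a number 15.4 percentage points higher (beyond the scatter) from compound 3 to compound 4, 5.8 percentage points apart, within the scatter of two such steps. The other change, hydroxy in place of hydrogen on an aromatic carbon, gives a number 19.3 percentage points higher from compound 2 to compound 4 (beyond the scatter), and it too can be compared across two cores: the same change on two cores in this assay, a number 13.5 percentage points higher (beyond the scatter) from compound 1 to compound 3 and a number 19.3 percentage points higher (beyond the scatter) from compound 2 to compound 4, 5.8 percentage points apart, within the scatter of two such steps. Within the data shown here, each change therefore carried from one core to the other with a step of similar size, but this rests on only two pairs per change, one dose and a percentage that is not a potency, so it shows neither a general rule for the series nor why the steps agree.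

The compounds shown leave open whether an amine or a carboxylic acid in place of the hydroxy, on the same aromatic carbon, would give a step of like size on both cores. They also leave open whether the steps would keep their size at another dose.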